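Swapping 3-cyanobenzyl for butyl: working notes

A few compounds are considered here, and "the series" means these few. Any claim that something is new, unique, unknown or untested is made for them only; others in the source may bear on it.

Of the compounds shown here, two have measured values so far. In a functional assay on RAW264.7 cells (Mus musculus) for inhibition, read by Griess assay, with stated times of 2 h and 24 h (on this read-out higher numbers stand for weaker inhibition and lower numbers for stronger inhibition), compound 1 (`C#CCOc1cc(O)c2c(c1)O[C@H](c1ccc(OC)c(O)c1)CC2=O`) gives 20900 nM. In this assay compound 2 (`COc1ccc([C@@H]2CC(=O)c3c(O)cc(OCc4cn(Cc5cccc(C#N)c5)nn4)cc3O2)cc1O`) gives 18000 nM, so compound 2 stands level with compound 1, the two values lying within the scatter of each other. No pair of measured compounds differs in one place only, so the effect of a single change on this read-out has not been shown.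

The next compound is compound 3 (`CCCCn1cc(COc2cc(O)c3c(c2)O[C@H](c2ccc(OC)c(O)c2)CC3=O)nn1`). Its difference from compound 2 is propyl in place of 3-cyanophenyl on a saturated chain carbon bound to an aromatic nitrogen. Read one bond further out, this is 3-cyanobenzyl to butyl.

With compound 1 at 20900 nM and compound 2 at 18000 nM, no step beyond the scatter is expected in this assay, and no firm direction can be given. The estimated 1.1-fold higher number from compound 2 to compound 3 (0.05 log units; within the scatter) is therefore expected to remain small. For compound 3 the estimate is 20000 nM, with an expected range from 8000 nM to 45000 nM.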

Compound 3, half-maximal inhibitory concentration: 13900 nM
Estimate against measurement, compound 3: 1.4-fold (0.16 log units) above; measured number inside the range.
By their numbers in this assay, from the lowest: compounds 3, 2 and 1 (each within the scatter of the next).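

For the compounds shown here, at the saturated chain carbon bound to an aromatic nitrogen, the first comparison in this assay that differs in one place only gives a 1.3-fold lower number from compound 2 to compound 3 (0.11 log units; within the scatter) and so does not separate butyl from 3-cyanobenzyl on this read-out, even though the exchange removes both the six-membered aromatic ring and the nitrile. A second single-place comparison, on a saturated chain carbon bound to an oxygen on an aromatic ring, gives a 1.5-fold lower number from compound 1 to compound 3 (0.18 log units; within the scatter) and likewise does not separate 1-butyl-1H-1,2,3-triazol-4-yl from ethynyl. No measurement is at hand that bears on the reason for either reading.

The compounds shown leave open whether any group on the chain carbon bound to the aromatic nitrogen can move the number beyond the scatter, for instance an amine, a carboxylic acid or a chain longer than butyl. They also do not separate the contribution of the nitrile from that of the aromatic ring in 3-cyanobenzyl, a distinction that a plain benzyl group at the same place would address.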